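From compound 2 to compound 3: another aromatic ring swap

The source may hold more compounds than are shown below. What is called first, only, known or untested is meant among the compounds shown, and "the series" means these compounds.

Measured in an ADME assay on BaF3 cells (Mus musculus) for antiproliferative activity, read by CCK-8 assay, with a stated time of 72 h; a higher number here means a weaker inhibitor of growth, a lower number a stronger inhibitor of growth:
- compound 1 `CN1CCN(Cc2ccc(NC(=O)CCSc3ccc4c(-c5ccncc5)n[nH]c4c3)cc2C(F)(F)F)CC1`: 1060 nM
- compound 2 `Cc1ccc(-c2n[nH]c3cc(SCCC(=O)Nc4ccc(CN5CCN(C)CC5)c(C(F)(F)F)c4)ccc23)cn1`: 1180 nM

Within the data shown here, compound 2 stands within the scatter of compound 1, the only other measured compound. Compound 3 `CN1CCN(Cc2ccc(NC(=O)CCSc3ccc4c(-c5cnn(C)c5)n[nH]c4c3)cc2C(F)(F)F)CC1` carries 1-methyl-1H-pyrazol-4-yl in place of 6-methylpyridin-3-yl on an aromatic carbon, 1-methyl-1H-pyrazol-4-yl in place of 6-methylpyridin-3-yl on an aromatic carbon. Among the measured compounds shown here, one measured step bears on this place: a 1.1-fold higher number from compound 1 to compound 2 (0.05 log units; within the scatter). A single step is thin evidence, and no five-membered ring has been measured here. Even so, no change beyond the scatter is expected in this assay, in either direction. The expected step is a 1.2-fold lower number from compound 2 to compound 3 (0.07 log units; within the scatter). The estimate for compound 3 is 1000 nM, with an expected range of 400 nM to 2500 nM.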

Compound 3, concentration for 50% growth inhibition: 1400 nM
For compound 3 the middle estimate is 1.4-fold (0.15 log units) below the measured one, within the range that was stated.
By their numbers in this assay, from the lowest: compounds 1, 2 and 3 (each within the scatter of the next).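

In this assay, a five-membered aromatic ring at this place gives a 1.2-fold higher number from compound 2 to compound 3 (0.07 log units; within the scatter) and a 1.3-fold higher number from compound 1 to compound 3 (0.12 log units; within the scatter) and so stays within the scatter. Across the three compounds shown, a six-membered aromatic ring with 1 hetero atom and a five-membered one with 2 hetero atoms read alike at this place on the shared core. No measurement shown bears on the reason for this. Still open, from the compounds shown here alone, is whether a non-aromatic group here, such as a morpholine, a primary amine or a carboxylic acid, would give a step beyond the scatter.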